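The source may hold more compounds than are shown below. What is called first, only, known or untested is meant among the compounds shown, and "the series" means these compounds.

Compound 1 `O=C(Nc1cccc(-n2cc(-c3ccncc3)c(-c3cc(O)cc(Cl)c3)n2)c1)Nc1ccc(Cl)c(Cl)c1` and compound 2 `COc1cc(Cl)cc(-c2nn(-c3cccc(NC(=O)Nc4ccc(Cl)c(Cl)c4)c3)cc2-c2ccncc2)c1` share one core and were both tested in a functional assay on OVCAR-8 cells (Homo sapiens) for inhibition, read by sulforhodamine B assay, with a stated time of 48 h, tested at 0.01 uM; a lower number here means a stronger effect, a higher number a weaker effect of the compound at the concentration tested. In this assay compound 1 gives 102%, and compound 2 gives 96%. Compound 2 holds the lowest of the two numbers, with compound 1 the nearest, but the gap is within the scatter, so no order can be read between them. Going by the values given here, the single measured step, a number 6 percentage points lower from compound 1 to compound 2 (within the scatter), concerns a methyl in place of hydrogen on an oxygen on an aromatic ring and does not touch the part that is changed next. Compound 3 `COc1cc(Cl)cc(-c2nn(-c3cccc(NC(=O)c4cccc(C(F)(F)F)c4)c3)cc2-c2ccncc2)c1` differs from compound 2 by 3-(trifluoromethyl)phenyl in place of (3,4-dichlorophenyl)amino on a carbonyl carbon. Among the compounds with values here, no measured step bears on this change, so the data give no direction for it, and for compound 3 the step of a number 1 percentage points higher from compound 2 to compound 3 (within the scatter) is expected to stay within the scatter. Compound 3 is estimated at 97% in this assay, with a range from 84% to 110%.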

Compound 3, a percentage reported as activity, at one concentration (the size of the read-out at that concentration, not a potency): 103%
The estimate for compound 3 lay 6 percentage points below the measured number; the range from low to high includes it.
By their numbers in this assay, from the lowest: compounds 2, 1 and 3 (each within the scatter of the next).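

Going by these compounds alone, the first change at the carbonyl carbon, away from the part touched by the methyl step, gives a number 7 percentage points higher from compound 2 to compound 3 (within the scatter) in this assay. At this position, therefore, 3-(trifluoromethyl)phenyl can stand in place of (3,4-dichlorophenyl)amino, which also removes one hydrogen-bond donor, without a readable change at the single concentration tested, so this swap gives no direction for the position. No supporting data are available to explain this result.

The compounds shown leave open whether an amine, a carboxylic acid or a longer alkyl chain in place of the 3-(trifluoromethyl)phenyl on the carbonyl carbon would move the number in this assay beyond the scatter. They also leave open whether any group at this position can separate itself from compound 2 in this read-out.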